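The source may report more compounds than this note shows. Statements on the series, on what has been measured and on what is new or still open speak of the compounds shown alone.

In a functional assay on SN12C cells (Homo sapiens) for inhibition, read by sulforhodamine B assay, with a stated time of 48 h (a lower number here means a stronger inhibitor of growth, a higher number a weaker inhibitor of growth), compound 2 (`COc1cccc(OC)c1/C=N/NC(=O)Cc1csc2nc(-c3ccc(Br)cc3)cn12`) gives 20900 nM and lies within the scatter of compound 1 (`O=C(Cc1csc2nc(-c3ccc(Br)cc3)cn12)N/N=C/c1ccccc1`) at 13200 nM on the same read-out. Compound 3 (`O=C(Cc1csc2nc(-c3ccc(Br)cc3)cn12)N/N=C/c1ccc(Cl)cc1Cl`) carries 2,4-dichlorophenyl in place of 2,6-dimethoxyphenyl on a carbon with a double bond to nitrogen. Among the compounds with values here, the one measured step at this place (a 1.6-fold higher number from compound 1 to compound 2 (0.20 log units; within the scatter)) is small, so no step beyond the scatter is expected in this assay and no firm direction can be drawn from it. The estimated move is a 1.3-fold lower number from compound 2 to compound 3 (0.12 log units; within the scatter) and remains a small one. Compound 3 is estimated at 16000 nM with an expected range of 7000 nM to 35000 nM in this series.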

Compound 3, concentration for 50% growth inhibition: 85100 nM
Beside the measured number, compound 3's estimate is 5.3-fold (0.73 log units) below it; measured number above the stated range.
By their numbers in this assay, from the lowest: compounds 1 and 2 (each within the scatter of the next); then compound 3.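

In this assay, the place on a carbon with a double bond to nitrogen now shows a change beyond the scatter, with 2,4-dichlorophenyl giving a 4.1-fold higher number from compound 2 to compound 3 (0.61 log units; beyond the scatter) and a 6.4-fold higher number from compound 1 to compound 3 (0.81 log units; beyond the scatter). Phenyl and 2,6-dimethoxyphenyl remain within the scatter of each other, so the ring here is not indifferent to every substitution, and 2,4-dichlorophenyl alone departs from that pair. No measurement on hand accounts for this shift.

Still open, going by these compounds, is whether a phenyl bearing one chlorine would show the same step. Also open, on these data alone, is how a phenyl carrying an amine or a carboxylic acid would read at this place.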